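The compounds below may be only part of what the source reports. "The series", "measured", "known", "first", "only" and "open" are said of these compounds alone.

Working notes on the series. Compound 1 `COC(=O)C1=C(C)NC(C)=C(C(=O)OCc2ccccc2)C1c1cccc([N+](=O)[O-])c1` gives 15 nM in a functional assay on HEK293 cells for antagonist activity at Voltage-dependent L-type calcium channel subunit alpha-1D (Rattus norvegicus), read by FLIPR; a higher number here means a weaker inhibitor, a lower number a stronger inhibitor. Within the data shown here, compound 2 `COC(=O)C1=C(C)NC(C)=C(C(=O)OC2Cc3ccccc3C2)C1c1cccc([N+](=O)[O-])c1` gives 43 nM in this assay, which is the higher of the two numbers measured so far; the only step that reaches it, a 2.9-fold higher number from compound 1 to compound 2 (0.46 log units; beyond the scatter), is the sole measured step in this assay.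

Compound 3 `COC(=O)C1=C(C)NC(C)=C(C(=O)OCCC(C)c2ccccc2)C1c1cccc([N+](=O)[O-])c1` carries 3-phenylbutyl in place of 2,3-dihydro-1H-inden-2-yl on an oxygen next to a carbonyl group. Among the measured compounds shown here, the one measured step that bears on this position, a 2.9-fold higher number from compound 1 to compound 2 (0.46 log units; beyond the scatter), shows that a change at the ester oxygen can move the number by a modest amount. The change to compound 3 goes the other way structurally, from a ring-bound group back to an open chain, so a modest move of the number in either direction, or none beyond the scatter, is the expectation.

Compound 3 is estimated at 25 nM in this assay, within 8 nM to 80 nM, meaning an expected step of a 1.7-fold lower number from compound 2 to compound 3 (0.24 log units; within the scatter).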

Compound 3, half-maximal inhibitory concentration: 11 nM
Estimate against measurement, compound 3: 2.3-fold (0.36 log units) above, within the range that was stated.
By their numbers in this assay, from the lowest: compounds 3 and 1 (each within the scatter of the next); then compound 2.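

In this assay, 3-phenylbutyl in place of 2,3-dihydro-1H-inden-2-yl on an oxygen next to a carbonyl group gives a step beyond the scatter (a 3.9-fold lower number from compound 2 to compound 3 (0.59 log units; beyond the scatter)), so the number at this position moves in both directions among the groups shown. Replacing phenyl with 2-phenylpropyl on a saturated chain carbon bound to that oxygen gives a step within the scatter (a 1.4-fold lower number from compound 1 to compound 3 (0.13 log units; within the scatter)), so the longer, branched open chain of compound 3 cannot be told apart from the benzyl group of compound 1. No supporting data on hand explain the difference between the ring-containing group and the open chains.

On these data alone, it remains open whether the branching methyl of 3-phenylbutyl matters, as an unbranched 3-phenylpropyl group would show. The compounds shown also leave open how this position responds to a group without a phenyl ring, such as a chain ending in an amine or a carboxylic acid.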